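The compounds below may be only part of what the source reports. "The series", "measured", "known", "first", "only" and "open" are said of these compounds alone.

Measured so far:

Compound 1, `COc1ccc(-c2[nH]c3ccc(OC)cc3c2C=C(C#N)C#N)cc1`, gives 590 nM in a functional assay on MDA-MB-231 cells (Homo sapiens) for antiproliferative activity, with a stated time of 4 days; a lower number here means a stronger inhibitor, a higher number a weaker inhibitor.
Compound 2, `CCCCc1ccc2[nH]c(-c3ccc(OC)cc3)c(C=C(C#N)C#N)c2c1`, gives 26 nM in this assay.

For the measured compounds named here, compound 2 holds the lowest of the two numbers measured in this assay, and the only measured step leads to it: a 23-fold lower number from compound 1 to compound 2 (1.36 log units; beyond the scatter). That step changed a group on the core of compound 2, and compound 1 lags by that step.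

Compound 3, `CCCCc1ccc2[nH]c(-c3ccc(C(F)(F)F)cc3)c(C=C(C#N)C#N)c2c1`, keeps the butyl of compound 2 and alters the other ring instead. The change computed from the two structures is: trifluoromethyl in place of methoxy on an aromatic carbon. Going by the values given here, no measured step touches this position, so the one step known says nothing direct about it; it only shows that compounds of this core can move over a wide span when a substituent is exchanged. Without a comparable measured exchange, the expectation for compound 3 is kept close to compound 2, with room for a moderate shift in either direction; the expected step is a 1.7-fold higher number from compound 2 to compound 3 (0.24 log units; within the scatter). Compound 3 is therefore estimated at 45 nM, in a range from 10 nM to 200 nM.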

Compound 3, half-maximal inhibitory concentration: 56 nM
Beside the measured number, compound 3's estimate is 1.2-fold (0.09 log units) below it, and the stated range covers the measured number.
By their numbers in this assay, from the lowest: compound 2; then compound 3; then compound 1.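

Swapping methoxy for trifluoromethyl on this aromatic carbon, para to a large group, gives a 2.2-fold higher number from compound 2 to compound 3 (0.33 log units; beyond the scatter) in this assay, so this position does register the exchange, though the step is modest. The exchange also alters more than one counted feature at once: the methoxy brings one hydrogen-bond acceptor and the trifluoromethyl none, and the heavy-atom count rises as well, so this single step cannot show which of these differences matters, if any. Nothing measured here explains the step.

What the compounds shown leave open is how this position would respond to groups of another kind, such as an amine, a carboxylic acid or a longer chain, and whether any of them would give a lower number than the methoxy of compound 2. Going by these compounds, it also remains open whether the same exchange would produce a step of similar size with the methoxy of compound 1 in place of the butyl on the other ring, since this exchange has been read only with the butyl present.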